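Swapping a methoxyphenyl arm for a fluorostyryl arm

The source may hold more compounds than are shown below. What is called first, only, known or untested is meant among the compounds shown, and "the series" means these compounds.

Of the compounds shown here, two sharing one fused core have been measured in a functional assay on MCF7 cells (Homo sapiens) for cytotoxicity, read by MTT assay, with a stated time of 2 days, tested at 10 uM; a higher number here means a weaker effect of the compound at the concentration tested, a lower number a stronger effect. Compound 1 `COc1ccc(-c2cc(C(C)=O)c3[nH]c(-c4ccccc4)cc3c2)cc1` gives 49.5%, and compound 2 `COc1ccc(-c2cc(C(C)=O)c3[nH]c(-c4ccc(F)cc4)cc3c2)cc1` gives 52.9%. Within the data shown here, the only step between them, a number 3.4 percentage points higher from compound 1 to compound 2 (within the scatter), is a fluoro in place of hydrogen on an aromatic carbon, and it leaves the pair within the scatter; compound 2 therefore stands highest of the two numbers only nominally. Compound 3 `CC(=O)c1cc(/C=C/c2ccc(F)cc2)cc2cc(-c3ccc(F)cc3)[nH]c12` differs from compound 2 in another place: 2-(4-fluorophenyl)ethenyl in place of 4-methoxyphenyl on an aromatic carbon. Among the measured compounds shown here, no measured step touches that position, so the single step on record gives no direction, and the expectation for compound 3 is a step of a number 2.9 percentage points lower from compound 2 to compound 3 (within the scatter), with no change beyond the scatter. The estimate for compound 3 in this assay is accordingly 50%, expected to fall between 30% and 70%.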

Compound 3, a percentage reported as activity, at one concentration (the size of the read-out at that concentration, not a potency): 67.4%
Compound 3: the middle estimate sits 17.4 percentage points below what was measured; measured number inside the range.
By their numbers in this assay, from the lowest: compounds 1 and 2 (each within the scatter of the next); then compound 3.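

In this assay, putting 2-(4-fluorophenyl)ethenyl in place of 4-methoxyphenyl gives a number 14.5 percentage points higher from compound 2 to compound 3 (beyond the scatter), so compound 3 has a weaker effect at the concentration tested. This shows that the aromatic carbon meta to the acetyl group is sensitive to what it carries, whereas the fluoro change elsewhere on the shared core gave only a number 3.4 percentage points higher from compound 1 to compound 2 (within the scatter). Nothing available explains why this arm weakens the effect.

On these data alone, the change alters the ethenyl link and the ring substituent together, so it remains open whether either alone would produce this step, as a plain 2-phenylethenyl or a directly attached 4-fluorophenyl at this carbon could show. Also open, as far as these compounds go, is how this position would respond to quite different groups, such as an amine or a carboxylic acid.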